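The source may report more compounds than this note shows. Statements on the series, on what has been measured and on what is new or still open speak of the compounds shown alone.

Four analogues sharing one core were compared in a functional assay on QG-56 cells (Homo sapiens) for cytotoxicity, read by MTT assay, with a stated time of 48 h; on this read-out higher numbers stand for weaker inhibition and lower numbers for stronger inhibition. Compound 1, `COc1cc(/C=C/C(=O)C2=C(/C=C/c3ccc(O)c(OC)c3)NC(=O)NC2c2ccccc2)ccc1O`, gives 50000 nM in this assay. Compound 2, `COc1cc(/C=C/C(=O)C2=C(/C=C/c3ccc(O)c(OC)c3)NC(=O)NC2c2ccc(C)cc2)ccc1O`, gives 100000 nM in this assay. The change from compound 1 to compound 2 is methyl in place of hydrogen on an aromatic carbon, and it made a 2.0-fold higher number from compound 1 to compound 2 (0.30 log units; within the scatter).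

Compound 3, `COc1cc(/C=C/C(=O)C2=C(/C=C/c3ccc(O)c(OC)c3)NC(=S)NC2c2ccccc2)ccc1O`, gives 100000 nM in this assay; its number stands level with that of compound 2 at the digits reported, and the two together are the highest of the three numbers. The difference between the core of compound 3 and the core of compound 1 is not broken down here.

Compound 4, `COc1cc(/C=C/C(=O)C2=C(/C=C/c3ccc(O)c(OC)c3)NC(=S)NC2c2ccc(C)cc2)ccc1O`, is not yet measured. It differs from compound 3 by methyl in place of hydrogen on an aromatic carbon, the same change as that from compound 1 to compound 2, at a place described in the same words. On the basis of that earlier step, the expected step from compound 3 to compound 4 is a 1.5-fold higher number from compound 3 to compound 4 (0.18 log units; within the scatter). Compound 4 is therefore estimated at 150000 nM in this assay, between 60000 nM and 400000 nM, an expectation that rests only on compound 3 giving 100000 nM and on the step of a 2.0-fold higher number from compound 1 to compound 2 (0.30 log units; within the scatter).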

Compound 4, half-maximal inhibitory concentration: 12500 nM
Estimate against measurement, compound 4: 12-fold (1.08 log units) above, outside the stated range (below it).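

In this assay the change from phenyl to 4-methylphenyl on the core of compound 3 gave an 8.0-fold lower number from compound 3 to compound 4 (0.90 log units; beyond the scatter) and so moved the number by more than the usual scatter. Set beside the earlier step, the same methyl in place of hydrogen did not carry over from one core to the other with the same result: the same change on two cores in this assay, a 2.0-fold higher number (0.30 log units; within the scatter) from compound 1 to compound 2 and an 8.0-fold lower number (0.90 log units; beyond the scatter) from compound 3 to compound 4, 16-fold (1.20 log units) apart, beyond the scatter of two such steps. This shows that, for these two pairs, a step measured on the core of compound 1 was no guide to the step on the core of compound 3, but it does not show why the two differ, and two pairs give no rule for any other core in the series.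

The compounds shown leave open whether an ethyl group, a methoxy group or a chlorine atom at the same place would also differ between the two cores. They also leave open how a methyl group at another place on the phenyl ring would behave on either core.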